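A few compounds are considered here, and "the series" means these few. Any claim that something is new, unique, unknown or untested is made for them only; others in the source may bear on it.

The measured compounds and their values in a functional assay on NCI-H1975 cells (Homo sapiens) for inhibition, read by sulforhodamine B assay, tested at 10 uM; on this read-out higher numbers stand for more inhibition at the one concentration tested (going by the name of the read-out) and lower numbers for less inhibition:

Compound 1, `CN1CCN(c2ccc(C3=NN(S(=O)(=O)C4CC4)C(c4ccc(N(C)C)cc4)C3)cc2)CC1`, gives 0.2%.
Compound 2, `CN1CCN(c2ccc(C3=NN(S(=O)(=O)c4ccc(F)cc4)C(c4ccc(N(C)C)cc4)C3)cc2)CC1`, gives 95.7%.
Compound 3, `CN1CCN(c2ccc(C3=NN(S(=O)(=O)c4ccc(Br)cc4)C(c4ccc(N(C)C)cc4)C3)cc2)CC1`, gives 70.8%.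

Compound 3 stands second highest of the three numbers. Its nearest neighbour is compound 2, which lies higher by a step beyond the scatter, and its furthest is compound 1, which lies far lower. The two large steps in the set, a number 95.5 percentage points higher from compound 1 to compound 2 (beyond the scatter) and a number 70.6 percentage points higher from compound 1 to compound 3 (beyond the scatter), both come from putting a substituted phenyl in place of cyclopropyl on the sulfonyl sulfur; the third, a number 24.9 percentage points lower from compound 2 to compound 3 (beyond the scatter), is a modest one and exchanges only the group on the aromatic carbon of that phenyl.

The unmeasured compound 4 is `CN1CCN(c2ccc(C3=NN(S(=O)(=O)c4ccc(OC(F)(F)F)cc4)C(c4ccc(N(C)C)cc4)C3)cc2)CC1`. It differs from compound 3 in one place: trifluoromethoxy in place of bromo on an aromatic carbon. The step that bears most directly on this change is a number 24.9 percentage points lower from compound 2 to compound 3 (beyond the scatter), since it too swaps the group on the same aromatic carbon and moved the number only modestly; the two large steps show that the phenyl on the sulfonyl, kept here, carried most of the activity. A modest step is therefore expected, downward or within the scatter, and the expected change is a number 6.8 percentage points lower from compound 3 to compound 4 (within the scatter). Compound 4 is estimated at 64%, with a range from 35% to 90%.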

Compound 4, a percentage reported as inhibition, at one concentration (the size of the read-out at that concentration, not a potency): 26.5%
The estimate for compound 4 lay 37.5 percentage points above the measured number; the measured number lies below the stated range.
By their numbers in this assay, from the lowest: compound 1; then compound 4; then compound 3; then compound 2.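

The group on this aromatic carbon, para to a large group, weighs far more than the exchange of fluoro for bromo alone suggested, with trifluoromethoxy giving two large falls (a number 44.3 percentage points lower from compound 3 to compound 4 (beyond the scatter); a number 69.2 percentage points lower from compound 2 to compound 4 (beyond the scatter)). A substituted phenyl on the sulfonyl sulfur therefore does not by itself keep the number high in this assay: the gain over cyclopropyl shrinks to a modest one with the 4-(trifluoromethoxy)phenyl (a number 26.3 percentage points higher from compound 1 to compound 4 (beyond the scatter)), whereas the 4-fluorophenyl and 4-bromophenyl both gave large gains. At this position the numbers now run from fluoro at the top, through bromo, down to trifluoromethoxy, with each step between them beyond the scatter.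

No measurement at hand accounts for trifluoromethoxy standing so far below bromo at this position. The compounds shown leave open how a chloro, a methoxy, a dimethylamino group or a carboxylic acid on this same aromatic carbon would read, and whether a plain phenyl on the sulfonyl sulfur would fall nearer compound 2 or compound 4.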